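A few compounds are considered here, and "the series" means these few. Any claim that something is new, unique, unknown or untested is made for them only; others in the source may bear on it.

Measured so far in an ADME assay on HEK293 cells (Homo sapiens) for cytotoxicity, with a stated time of 72 h; on this read-out lower numbers stand for an effect already at smaller amounts and higher numbers for an effect only at larger amounts of compound:
Compound 1 `C=C[C@@](C)(/C=C/c1ccc(OC)cc1)CCC=C(C)C`: > 36600 nM
Compound 2 `C=C[C@@](C)(/C=C/c1ccc(Nc2ccccc2)cc1)CCC=C(C)C`: > 36600 nM
Compound 3 `C=C[C@@](C)(/C=C/c1ccc(Nc2ccc(Cl)cc2)cc1)CCC=C(C)C`: > 36600 nM

Compound 2 stands at > 36600 nM, which is a limit of this assay and not a number. The two other compounds sit at the same limit, so none of the three has a measured number.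

Compound 4 `C=C[C@@](C)(/C=C/c1ccc(Nc2cccc(C(F)(F)F)c2)cc1)CCC=C(C)C` is compound 2 with a single change: trifluoromethyl in place of hydrogen on an aromatic carbon. A group thus replaces a hydrogen on an aromatic carbon.

The closest measured parallel is a step that the two limits leave unreadable from compound 2 to compound 3, where chloro replaces hydrogen on an aromatic carbon. Two further steps bear on the question less directly: a step that the two limits leave unreadable from compound 1 to compound 2 and a step that the two limits leave unreadable from compound 1 to compound 3. Neither of these has a readable size, and the same holds for the chloro step, so none of them gives a direction. What they do show is a shared position, (the limit of > 36600 nM in this assay, at which 3 of the 3 values shown sit).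

On that basis, no step beyond the usual scatter is expected, and the most likely result is another report of a limit. The estimated step is a number no higher from compound 2 to compound 4 (the limit leaves the size open). The expected value for compound 4 is 36600 nM, with an estimated range from 18000 nM to 60000 nM.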

Compound 4, half-maximal effective concentration: > 36600 nM
Compound 4: a limit, no number (the forecaster's own chance of this, stated with the estimate: 75%); the middle value sits exactly at the limit.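

Compound 4 gives > 36600 nM in this assay, which is a limit and not a number, so its step from compound 2 cannot be read, and all four compounds now share one position: the limit of > 36600 nM in this assay, at which 4 of the 4 values shown sit.

The compounds shown leave open what amount of any of them affects these cells, and whether swapping the groups changes that amount at all.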